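A few compounds are considered here, and "the series" means these few. Any claim that something is new, unique, unknown or untested is made for them only; others in the source may bear on it.

Working notes on the series. Going by the values given here, in a functional assay on BT-483 cells (Homo sapiens) for cytotoxicity, read by MTT assay, with a stated time of 24 h (a higher number here means a weaker inhibitor, a lower number a stronger inhibitor), compound 1 (`CCNc1cc(-c2ccc(NC(=O)Nc3ccc(C(F)(F)F)cc3)cc2C)ccn1`) gives 19700 nM, and this is the only exact number available so far. Compound 2 (`CCNc1cc(-c2ccc(NC(=O)Nc3cccc4ccccc34)cc2C)ccn1`) reads > 30000 nM, which is a limit of the assay. Compound 1 therefore cannot yet be ranked against a second exact value.

Among the compounds with values here, the one measured step is an at least 1.5-fold higher number from compound 1 to compound 2 (0.18 log units; that floor lies within the scatter). Its floor lies within the scatter, and it concerns a different place in the molecule from the change now in question.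

Compound 3 (`CCNc1cc(-c2ccc(NC(=O)Nc3ccc(C(F)(F)F)cc3)cc2OC)ccn1`) differs from compound 1 by methoxy in place of methyl on an aromatic carbon. In words, this is methoxy in place of methyl on an aromatic carbon, ortho to a 2-(ethylamino)pyridin-4-yl group. Within the data shown here, no measured step covers this change, so the series gives no size or direction to carry over. No step beyond the scatter is expected in this assay, and the starting point stays compound 1 at 19700 nM.

The expected outcome is a 1.0-fold higher number from compound 1 to compound 3 (0.01 log units; within the scatter). The estimated value for compound 3 is 20000 nM, with an expected range of 10000 nM to 30000 nM.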

Compound 3, half-maximal inhibitory concentration: 25600 nM
Estimate against measurement, compound 3: 1.3-fold (0.11 log units) below; the measured number falls inside the stated range.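

In this assay, the position ortho to a 2-(ethylamino)pyridin-4-yl group now has its first measured change, methoxy in place of methyl, and the result is a 1.3-fold higher number from compound 1 to compound 3 (0.11 log units; within the scatter). This exchange adds one heavy atom and one hydrogen-bond acceptor, yet the two exact values stay within the scatter of each other, so neither group can be ranked above the other at this position. The earlier compounds gave only a step at the amide-type nitrogen with a floor rather than an exact size, and compound 2 still reads as a limit, not a number: the limit of > 30000 nM in this assay, at which 1 of the 3 values shown sits.

The compounds shown carry only methyl and methoxy at this position, so it remains open whether an amine, a carboxylic acid or a longer chain such as ethoxy there would give a step beyond the scatter. On these data alone, it also remains open whether methoxy in place of methyl would give the same result with naphthalen-1-yl in place of 4-(trifluoromethyl)phenyl on the amide-type nitrogen.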